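The source may report more compounds than this note shows. Statements on the series, on what has been measured and on what is new or still open speak of the compounds shown alone.

Measured in a functional assay on aorta (VSMC cells, Rattus norvegicus); a higher number here means that more compound is needed for the effect, a lower number that less compound is needed:
- compound 1 `CC(C)SC1=NS(=O)(=O)c2cc(Cl)ccc2N1`: 23000 nM
- compound 2 `CC(SC1=NS(=O)(=O)c2cc(Cl)ccc2N1)c1ccccc1`: 5400 nM
- compound 3 `CC(C)OC1=NS(=O)(=O)c2cc(Cl)ccc2N1`: 22700 nM

Compound 3 stands level with compound 1, as a 1.0-fold lower number from compound 1 to compound 3 (0.01 log units; within the scatter) shows. Only compound 2 has a clearly lower number.

The next compound, compound 4 `CC(C)CC1=NS(=O)(=O)c2cc(Cl)ccc2N1`, has isobutyl in place of isopropoxy on a carbon with a double bond to nitrogen.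

Among the measured compounds shown here, two measured steps bear on this. The closer one is a 1.0-fold lower number from compound 1 to compound 3 (0.01 log units; within the scatter), a swap at this same place, where isopropoxy replaced isopropylsulfanyl. The other, a 4.3-fold lower number from compound 1 to compound 2 (0.63 log units; beyond the scatter), is modest, but it brought in phenyl further out on the chain, and isobutyl adds no ring. For the measured compounds named here, no measured compound has a chain joined to the core through carbon, so this guide is imperfect.

In this assay, no step beyond the scatter is therefore expected, and the estimated change is a 1.1-fold lower number from compound 3 to compound 4 (0.05 log units; within the scatter).

For compound 4 the expected value is 20000 nM.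

The estimated range for compound 4 runs from 7000 nM to 50000 nM.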

Compound 4, half-maximal effective concentration in the VSMC assay: 5800 nM
For compound 4 the middle estimate is 3.4-fold (0.54 log units) above the measured one; measured number below the stated range.
By their numbers in the VSMC assay, from the lowest: compounds 2 and 4 (each within the scatter of the next); then compounds 3 and 1 (each within the scatter of the next).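

In the VSMC assay isopropoxy and isopropylsulfanyl stood level on this carbon, so the position could have seemed indifferent to what is placed there. Isobutyl, whose entering group has no hydrogen-bond acceptor, shows otherwise: in the VSMC assay it gives a 3.9-fold lower number from compound 3 to compound 4 (0.59 log units; beyond the scatter) and also a 4.0-fold lower number from compound 1 to compound 4 (0.60 log units; beyond the scatter). The same swap also means that the proton is given up less readily, as a physicochemical assay for acid dissociation, shows: the measured acid dissociation constant of compound 3, 8, and of compound 4, 8.52, a number 0.52 log units higher (beyond the scatter). In the physicochemical assay compound 3 gives 8 and compound 4 gives 8.52.

One pair of compounds cannot tell whether this shift in the proton's release accounts for the lower number, since the oxygen and the hydrogen-bond acceptor leave at the same time. As far as these compounds go, how a longer carbon chain, an amine or a carboxylic acid would behave on this carbon also remains open.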